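The source may hold more compounds than are shown below. What is called first, only, known or untested is meant among the compounds shown, and "the series" means these compounds.

Compound 1 `CC(C)C(=O)Nc1cccc(C(=O)/C=C2/C(=O)Nc3ccccc32)c1` is measured in a functional assay on BGC-823 cells (Homo sapiens) for inhibition, read by MTT assay, with a stated time of 72 h (on this read-out lower numbers stand for stronger inhibition and higher numbers for weaker inhibition), where compound 1 gives 6200 nM. Two other compounds share its core. Compound 3 `CCC(=O)Nc1cccc(C(=O)/C=C2/C(=O)Nc3ccccc32)c1` gives 7500 nM, and compound 2 `O=C1Nc2ccccc2/C1=C\C(=O)c1ccccc1F` gives 11800 nM. Compound 1 holds the lowest of the three numbers, but its distance to compound 3 and to compound 2 lies within the scatter, so no order among the three can be claimed. Among the compounds with values here, the one step that differs in a single place runs a 1.2-fold higher number from compound 1 to compound 3 (0.08 log units; within the scatter), where hydrogen replaces methyl on a saturated chain carbon bound to a carbonyl carbon and a saturated chain carbon.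

Compound 4 `Nc1cccc(C(=O)/C=C2/C(=O)Nc3ccccc32)c1` differs from compound 1 by hydrogen in place of isopropylcarbonyl on a nitrogen on an aromatic ring. This removes the whole isopropylcarbonyl from the nitrogen on the aromatic ring, leaving amino. Within the data shown here, only the step from compound 1 to compound 3 touches this chain, and it shortened the chain by one carbon without moving the number beyond the scatter. Among the measured compounds shown here, no measured step removes the acyl group entirely, so the data give no direction for a larger change. Compound 4 is therefore expected to sit close to compound 1, with an estimated step of a 1.3-fold higher number from compound 1 to compound 4 (0.11 log units; within the scatter). The estimate for compound 4 is 8000 nM, between 3500 nM and 20000 nM.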

Compound 4, half-maximal inhibitory concentration: 29900 nM
For compound 4 the middle estimate is 3.7-fold (0.57 log units) below the measured one, outside the stated range (above it).
By their numbers in this assay, from the lowest: compounds 1, 3 and 2 (each within the scatter of the next); then compound 4.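

Taking the acyl group off the nitrogen on the aromatic ring altogether gives a 4.8-fold higher number from compound 1 to compound 4 (0.68 log units; beyond the scatter) in this assay and, read from the propanoyl amide, a 4.0-fold higher number from compound 3 to compound 4 (0.60 log units; beyond the scatter) as well; both steps are modest but lie beyond the scatter. Within the data shown here, this is the first change at this position that moves the number beyond the scatter, whereas the earlier step within the acyl chain, a 1.2-fold higher number from compound 1 to compound 3 (0.08 log units; within the scatter), did not. Among compounds 1, 3 and 4, then, whether this nitrogen carries an acyl group counts for more than which of the two acyl groups it carries.

From the compounds shown here alone, what remains open is whether a longer chain such as hexanoyl, a benzoyl group, a methanesulfonyl group or a plain methyl on the same nitrogen would keep the number near that of compound 1 or let it rise towards that of compound 4. Compound 2 differs from compound 4 in more than one place, so it cannot be read against this step. Nothing given here bears on why the number rises when the acyl group is lost.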